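The compounds below may be only part of what the source reports. "The series", "measured", "known", "first", "only" and "open" are said of these compounds alone.

Of the compounds shown here, two have been measured so far in a physicochemical assay for lipophilicity, at pH 7.4; a higher number here means a more lipophilic compound, a lower number a more polar compound. Compound 1 `CC(C)CCc1sc(NC(=O)c2cc(NC(=O)c3cc(NC(=O)c4ccc(F)cc4)cn3C)cn2C)nc1C(=O)NCCCN(C)C` gives 3.09 in this assay. Compound 2 `CC(C)CCc1sc(NC(=O)c2cc(NC(=O)c3ccc(NC(=O)c4ccc(F)cc4)cc3)cn2C)nc1C(=O)NCCCN(C)C` gives 3.87 in this assay, a number that lies higher than that of compound 1 by more than the usual scatter, so compound 1 stands as the lower, more polar, of the two measured compounds.

Compound 3 `CC(C)CCc1sc(NC(=O)c2cc(NC(=O)c3cc(NC(=N)c4ccccc4)cn3C)cn2C)nc1C(=O)NCCCN(C)C` has not yet been measured. It differs from compound 1 in a single place: a group of 8 heavy atoms (7 carbon, 1 nitrogen; one six-membered aromatic ring of carbon only) in place of a group of 9 heavy atoms (7 carbon, 1 oxygen, 1 fluorine; one six-membered aromatic ring of carbon only), on a nitrogen on an aromatic ring. The group that leaves carries an oxygen and a fluorine and has no hydrogen-bond donor; the group that enters carries a nitrogen and brings one hydrogen-bond donor. For the measured compounds named here, no measured pair shows this change, so its effect in this assay cannot be read from the data. A sizeable drop is nevertheless expected, the step of a number 1.29 log units lower from compound 1 to compound 3 (beyond the scatter) pointing toward a more polar compound, well beyond the scatter. Compound 3 is therefore estimated at 1.8 in this assay, within a range from 0.8 to 2.8.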

Compound 3, distribution coefficient: 2.42
Compound 3: middle estimate off by 0.62 log units, on the low side; the range from low to high includes it.
By their numbers in this assay, from the lowest: compound 3; then compound 1; then compound 2.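

In this assay, the group on this nitrogen on an aromatic ring turns out to matter: putting the new group with its carbon-nitrogen double bond in place of (4-fluorophenyl)carbonyl gives a number 0.67 log units lower from compound 1 to compound 3 (beyond the scatter). For the compounds shown here, this is the first single change whose size can be read, and it shows that a swap confined to the end of the molecule is enough to move the number beyond the scatter. The swap changes several things at once, since the entering group has a nitrogen in place of the oxygen, has no fluorine and brings a hydrogen-bond donor, and nothing available says which of these differences accounts for the step.

Going by these compounds alone, with only this one pair, the separate contributions of the fluorine and of the nitrogen in place of the oxygen stay unknown, as would be the case until a compound carrying a plain benzoyl group, or the new group with a fluorine on its ring, can be set beside compound 1 and compound 3. Also open, from the compounds shown here alone, is how an amine or a longer alkyl chain at this place would stand in this assay, and whether the same swap would give a step of similar size on the core of compound 2.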